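Exchanging the anilino aryl group in a hydroxamate series

A few compounds are considered here, and "the series" means these few. Any claim that something is new, unique, unknown or untested is made for them only; others in the source may bear on it.

Three compounds sharing one core were measured in a functional assay on RPMI-8226 cells (Homo sapiens) for antiproliferative activity, read by radiometric assay, with a stated time of 72 h; a higher number here means a weaker inhibitor, a lower number a stronger inhibitor. Compound 1 `Cc1cc(F)ccc1Nc1ncnc2cc(NC(=O)CCCCCCC(=O)NO)sc12` gives 1950 nM in this assay. Compound 2 `Cc1ccc(F)c(Nc2ncnc3cc(NC(=O)CCCCCCC(=O)NO)sc23)c1` gives 1060 nM, and compound 3 `COc1ccc(Nc2ncnc3cc(NC(=O)CCCCCCC(=O)NO)sc23)c(C)c1` gives 1980 nM. The step of a 1.8-fold lower number from compound 1 to compound 2 (0.26 log units; within the scatter) and the step of a 1.0-fold higher number from compound 1 to compound 3 (0.01 log units; within the scatter) both fall within the scatter, so compound 1 cannot be separated from either neighbour, and the step of a 1.9-fold higher number from compound 2 to compound 3 (0.27 log units; within the scatter) is likewise within it.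

Compound 4 `CCc1ccc(Nc2ncnc3cc(NC(=O)CCCCCCC(=O)NO)sc23)cc1` is not yet measured. It differs from compound 1 by 4-ethylphenyl in place of 4-fluoro-2-methylphenyl on a nitrogen on an aromatic ring. Every measured step that swaps the aryl group or one of its substituents stayed within the scatter, so no step beyond it is expected. The estimated step is a 1.1-fold lower number from compound 1 to compound 4 (0.03 log units; within the scatter). Compound 4 is estimated at 1800 nM, with a range from 800 nM to 4000 nM.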

Compound 4, half-maximal inhibitory concentration: 2540 nM
Compound 4: the middle estimate sits 1.4-fold (0.15 log units) below what was measured; measured number inside the range.
By their numbers in this assay, from the lowest: compounds 2, 1, 3 and 4 (each within the scatter of the next, the first and the last beyond it).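

In this assay, the exchange on this nitrogen first gives a step beyond the scatter, though a modest one (a 2.4-fold higher number from compound 2 to compound 4 (0.38 log units; beyond the scatter)). That step depends on the comparison, since the same 4-ethylphenyl group stays within the scatter against the other two aryl groups (a 1.3-fold higher number from compound 1 to compound 4 (0.11 log units; within the scatter); a 1.3-fold higher number from compound 3 to compound 4 (0.11 log units; within the scatter)). Nothing available accounts for this difference.

Still open, going by these compounds, is whether an amine or a carboxylic acid on the aryl ring, or a pyridine in place of it, would move the number further. The compounds shown also leave open how a shorter or longer hydroxamate chain would behave.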